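Swapping pyridin-2-yl for 4-fluorophenyl on a shared core

This account rests on a few compounds, and the source may have more. Where it says the series, first, only, none or still open, it means among the compounds named here.

Compound 1 `COc1cc2c(cc1OC)CN(c1ccc(C=O)cc1)CC2`: 6600 nM
Compound 2 `COc1cc2c(cc1OC)CN(c1ccccn1)CC2`: 800 nM

Both numbers come from a physicochemical assay for solubility, read by LC-MS, in phosphate buffer, with a stated time of 20 min, at pH 7.0, tested at 100 uM; a lower number here means a less soluble compound, a higher number a more soluble compound. Compound 2 has the lower number of the two, and its gap to compound 1 lies beyond the usual scatter of repeated measurements.

The next compound, compound 3 `COc1cc2c(cc1OC)CN(c1ccc(F)cc1)CC2`, keeps the core of compound 2 and changes one group: 4-fluorophenyl in place of pyridin-2-yl on an amine nitrogen in a ring.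

Among the compounds with values here, no measured pair differs in just one place, so the data offer no direct guide to the size of this change. Within the data shown here, compound 1 at 6600 nM and compound 2 at 800 nM show only that two compounds sharing this core can sit far apart. In this assay, the expectation is therefore a slight rise at most, with no step beyond the scatter, though with wide uncertainty. The estimate amounts to a 1.3-fold higher number from compound 2 to compound 3 (0.10 log units; within the scatter), an expected step that stays within the scatter. The estimated value for compound 3 is 1000 nM, with an expected range of 200 nM to 5000 nM.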

Compound 3, solubility: 20300 nM
Compound 3: the middle estimate sits 20-fold (1.31 log units) below what was measured, outside the stated range (above it).
By their numbers in this assay, from the lowest: compound 2; then compound 1; then compound 3.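

In this assay, putting 4-fluorophenyl in place of pyridin-2-yl on the amine nitrogen in a ring gives a 25-fold higher number from compound 2 to compound 3 (1.40 log units; beyond the scatter), so the group held at this position can shift the read-out strongly even though the rest of the molecule stays the same. The same aromatic ring can also respond to a smaller edit: fluoro in place of formyl on an aromatic carbon gives a 3.1-fold higher number from compound 1 to compound 3 (0.49 log units; beyond the scatter), a modest step that still lies beyond the usual scatter, and compound 3 ends up with the highest number of the three. Nothing shown here explains the size of either step.

The larger step combines two edits, since the ring loses its nitrogen and gains a fluorine, so a plain phenyl group on the same nitrogen would be needed to tell how much each edit contributes. As far as these compounds go, it also remains open how the read-out would respond to a group such as an amine or a carboxylic acid in place of the fluoro on that aromatic carbon.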